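The compounds below may be only part of what the source reports. "The series", "measured", "known", "first", "only" and "open" are said of these compounds alone.

In a functional assay on HL-60 cells (Homo sapiens) for antiproliferative activity, with a stated time of 72 h (on this read-out lower numbers stand for stronger inhibition and higher numbers for weaker inhibition), compound 3 (`COc1ccc(CNc2ncnc3c2ncn3[C@@H]2O[C@H](CO)[C@@H](O)[C@H]2O)c(OC)c1`) gives 39000 nM and lies within the scatter of compound 1 (`OC[C@H]1O[C@@H](n2cnc3c(NCc4ccc(Br)cc4)ncnc32)[C@H](O)[C@@H]1O`) with its 47400 nM while compound 2 (`COc1cccc(CNc2ncnc3c2ncn3[C@@H]2O[C@H](CO)[C@@H](O)[C@H]2O)c1`) stands apart with the lowest number at 4900 nM so far. In compound 4 (`OC[C@H]1O[C@@H](n2cnc3c(NCc4ccc(F)cc4Cl)ncnc32)[C@H](O)[C@@H]1O`) 2-chloro-4-fluorophenyl enters in place of 2,4-dimethoxyphenyl on a saturated chain carbon bound to a nitrogen on an aromatic ring (2-chloro-4-fluorophenyl in place of 2,4-dimethoxyphenyl on a saturated chain carbon bound to a nitrogen on an aromatic ring). Exchanges at this place gave a 1.2-fold lower number from compound 1 to compound 3 (0.08 log units; within the scatter) between 4-bromophenyl and 2,4-dimethoxyphenyl. The two modest steps, a 9.7-fold lower number from compound 1 to compound 2 (0.99 log units; beyond the scatter) and an 8.0-fold higher number from compound 2 to compound 3 (0.90 log units; beyond the scatter) both involve the 3-methoxyphenyl of compound 2, a group absent from compound 4. No step beyond the scatter is therefore expected in this assay and the estimated step is small (a 1.1-fold lower number from compound 3 to compound 4 (0.05 log units; within the scatter)). For compound 4 the estimated value is 35000 nM (expected range 12000 nM to 90000 nM).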

Compound 4, half-maximal inhibitory concentration: 9000 nM
For compound 4 the middle estimate is 3.9-fold (0.59 log units) above the measured one; measured number below the stated range.
By their numbers in this assay, from the lowest: compounds 2 and 4 (each within the scatter of the next); then compounds 3 and 1 (each within the scatter of the next).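

At this place, on a saturated chain carbon bound to a nitrogen on an aromatic ring, 2-chloro-4-fluorophenyl gives a 4.3-fold lower number from compound 3 to compound 4 (0.64 log units; beyond the scatter) and a 5.3-fold lower number from compound 1 to compound 4 (0.72 log units; beyond the scatter) while a 1.8-fold higher number from compound 2 to compound 4 (0.26 log units; within the scatter) stays within the scatter. In this assay a group without methoxy substituents thus joins 3-methoxyphenyl in standing apart from compound 1 and compound 3, so a methoxy group is not needed for that level. Nothing available explains these differences.

The compounds shown leave open whether the chlorine or the fluorine alone would give the same number. Going by these compounds, how an amine, a carboxylic acid or a longer chain at this place would read also remains open.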